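Compound 3 and a larger ring

A few compounds are considered here, and "the series" means these few. Any claim that something is new, unique, unknown or untested is made for them only; others in the source may bear on it.

In a physicochemical assay for solubility, read by chemiluminescence, measured as kinetic solubility (on this read-out lower numbers stand for lower solubility and higher numbers for higher solubility), compound 1 (`Clc1ccc(CNc2ccnc(N3CCC4(CCN(C[C@H]5CCCN5)C4)CC3)n2)c(Cl)c1`) reads 16 ug/mL and compound 2 (`Clc1ccc(CNc2ccnc(N3CCC4(CCN(CC5CCCN5)C4)CC3)n2)c(Cl)c1`) reads 270 ug/mL on the same scale. Compound 3 (`Clc1ccc(CNc2ccnc(N3CCC4(CCN(C[C@@H]5CCCN5)C4)CC3)n2)c(Cl)c1`) stands between them at 56 ug/mL as the second highest of the three. Compound 4 (`Clc1ccc(CNc2ccnc(N3CCC4(CCN(CC5CCCCN5)C4)CC3)n2)c(Cl)c1`) differs from compound 3 as follows: piperidin-2-yl in place of pyrrolidin-2-yl on a saturated chain carbon bound to an amine nitrogen in a ring on a saturated chain carbon bound to an amine nitrogen in a ring.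

For the measured compounds named here, no measured step makes this ring swap. The steps at hand concern only how one stereocentre is drawn, and all lie beyond the scatter: a modest one (a 3.5-fold higher number from compound 1 to compound 3 (0.54 log units; beyond the scatter)), a large one (a 17-fold higher number from compound 1 to compound 2 (1.23 log units; beyond the scatter)) and another modest one (a 4.8-fold lower number from compound 2 to compound 3 (0.68 log units; beyond the scatter)). The last reflects the fact that one of compounds 2 and 3 is drawn with a defined configuration and the other without, at the place where they differ as its sole structural difference. Compound 4 also carries no drawn configuration, as does compound 2 (270 ug/mL), so a modest rise is the best guess. From the compounds shown here alone, the expected change is a 2.1-fold higher number from compound 3 to compound 4 (0.33 log units; beyond the scatter) in this assay with real uncertainty, since the ring swap itself is untested. Compound 4 is estimated at 120 ug/mL (range 25 ug/mL to 400 ug/mL) in this assay once measured.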

Compound 4, solubility: 182 ug/mL
Compound 4: the middle estimate sits 1.5-fold (0.18 log units) below what was measured; the measured number falls inside the stated range.
By their numbers in this assay, from the lowest: compound 1; then compound 3; then compounds 4 and 2 (each within the scatter of the next).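

In this assay, for the compounds shown here, only one step swaps the ring while neither compound has a drawn configuration (a 1.5-fold lower number from compound 2 to compound 4 (0.17 log units; within the scatter)). Going by these compounds alone, at this place, on a saturated chain carbon bound to an amine nitrogen in a ring, piperidin-2-yl and pyrrolidin-2-yl therefore cannot be told apart, something the earlier compounds, which all carry pyrrolidin-2-yl, could not show. The other two steps (a 3.3-fold higher number from compound 3 to compound 4 (0.51 log units; beyond the scatter); an 11-fold higher number from compound 1 to compound 4 (1.06 log units; beyond the scatter)) change the ring and the drawn configuration together, so they cannot be credited to the ring alone.

Within the data shown here, still open is whether piperidin-2-yl drawn as a single configuration would show a split like the one between compound 1 and compound 3. Also open, from the compounds shown here alone, is how morpholin-3-yl or an open-chain amine would read at this place.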